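The compounds below may be only part of what the source reports. "The series", "measured", "known", "first", "only" and "open" are said of these compounds alone.

Measured so far:

Compound 1, `CC1(C)N=C(N)N=C(N)N1c1ccc(OCc2ccc(S(=O)(=O)F)cc2)c(Cl)c1`: 7.58
Compound 2, `CC1(C)N=C(N)N=C(N)N1c1ccc(OCc2ccc(S(=O)(=O)F)c(Cl)c2)c(Cl)c1`: 7.43
Compound 3, `CC1(C)N=C(N)N=C(N)N1c1cccc(CCCCc2cccc(S(=O)(=O)F)c2)c1`: 8.1

All three compounds were tested in an assay on isolated protein for inhibition of Dihydrofolate reductase (Mus musculus); on this read-out lower numbers stand for lower potency and higher numbers for higher potency (the scale is a negative logarithm). Compound 1 and compound 2 share a core and differ in one place: chloro in place of hydrogen on an aromatic carbon. That change gave a number 0.15 log units lower from compound 1 to compound 2 (within the scatter), so the two numbers cannot be told apart. Compound 3 rests on a different core; the difference between the core of compound 1 and the core of compound 3 is not broken down here. Among the three, compound 3 gives the highest number, and its distance to compound 1 and to compound 2 lies beyond the usual scatter.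

Compound 4, `CC1(C)N=C(N)N=C(N)N1c1cccc(CCCCc2ccc(Cl)c(S(=O)(=O)F)c2)c1`, is the untested partner of compound 3. It differs from compound 3 by chloro in place of hydrogen on an aromatic carbon. Among the compounds with values here, this is the same kind of change as the one from compound 1 to compound 2, but not the same: in compound 2 the chloro sits meta to a large group, whereas in compound 4 it sits para to a large group. An estimate for compound 4 in this assay can rest only on this one precedent. The expected step is a number 0.15 log units lower from compound 3 to compound 4 (within the scatter), a small move because a number 0.15 log units lower from compound 1 to compound 2 (within the scatter) stayed within the scatter, with a somewhat wider range to allow for the changed surroundings of the chloro. Compound 4 is therefore estimated at 7.95, most likely between 7.4 and 8.5.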

Compound 4, logarithm of the reciprocal of the active concentration, log(1/C): 8.37
Compound 4: middle estimate off by 0.42 log units, on the low side; the range from low to high includes it.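

The chloro in place of hydrogen on an aromatic carbon gave a number 0.27 log units higher from compound 3 to compound 4 (within the scatter) in this assay, so these two numbers cannot be told apart. The same change on the core of compound 1 also stayed within the scatter, and the two steps do not differ measurably: the same change on two cores in this assay, a number 0.15 log units lower (within the scatter) from compound 1 to compound 2 and a number 0.27 log units higher (within the scatter) from compound 3 to compound 4, 0.42 log units apart, within the scatter of two such steps. Within the data shown here, this suggests that, on these two cores, the chloro can be carried across without a clear shift in the number, but the claim rests on only two pairs; it does not show that the same would hold on a third core, and it gives no reason for the result.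

The compounds shown leave open how a bromo or a methyl in place of the chloro would read, and whether a sulfonamide or a carboxylic acid in place of the fluorosulfonyl group would keep the number where it stands. Among these compounds, they also leave open what a shorter or a longer chain in place of the one in compound 3 would do, and whether a chloro on another carbon of the same ring would give a step of similar size.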